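The compounds below may be only part of what the source reports. "The series", "measured", "known", "first", "only" and "open" are said of these compounds alone.

Compounds measured in a functional assay on HBL-100 cells (Homo sapiens) for antiproliferative activity, read by sulforhodamine B assay, with a stated time of 48 h; on this read-out higher numbers stand for weaker inhibition of growth and lower numbers for stronger inhibition of growth:

Compound 1 `CCCCCCC(C#CC(=O)O)O/C=C/C(=O)OC`: > 100000 nM, a limit and not a number.
Compound 2 `CCCC(C#CC(=O)OC)O/C=C/C(=O)OC`: 270 nM.

Compound 1 stands at the weak end of what is shown, at the limit of > 100000 nM in this assay, at which 1 of the 2 values shown sits. Its true value in this assay is therefore unknown. Compound 3 `COC(=O)/C=C/OC(C#CC(=O)O)C(C)(C)C` comes from compound 1 by one change: tert-butyl in place of hexyl on a saturated chain carbon bound to an oxygen on an unsaturated carbon and a triple-bonded carbon. In words, tert-butyl stands in place of hexyl on a saturated chain carbon bound to an oxygen on an unsaturated carbon and a triple-bonded carbon. Within the data shown here, no measured pair shows what a change at this place does, so the size of the step remains a judgement. Only a small move towards stronger inhibition of growth is expected, or none beyond the scatter. The expected step is an at least 1.2-fold lower number from compound 1 to compound 3 (0.09 log units; that floor lies within the scatter). The estimate for compound 3 is 80000 nM, with an expected range of 20000 nM to 200000 nM.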

Compound 3, concentration for 50% growth inhibition: > 100000 nM
Compound 3 gave a limit, no number; the forecaster's own chance of this, stated with the estimate: 60%; at least 1.2-fold (0.09 log units) between middle value and limit.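

Among these compounds, compound 3, like compound 1, gives a limit and not a number in this assay, so no step between these two compounds can be read: the limit of > 100000 nM in this assay, at which 2 of the 3 values shown sit. The compounds shown leave open whether tert-butyl in place of hexyl changes inhibition of growth at all.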